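Removing one chloro on two related cores

This account rests on a few compounds, and the source may have more. Where it says the series, first, only, none or still open, it means among the compounds named here.

The set contains two cores that share a cyclic enaminone bearing a dithioester. Compound 1 `CCCCCCCCCCCSC(=S)C1=C(Nc2ccc(Cl)cc2Cl)CC(C)(C)CC1=O` carries an undecyl chain on the sulfur, while compound 2 `CC(=O)OC[C@H]1O[C@@H](SC(=S)C2=C(Nc3ccc(Cl)cc3Cl)CC(C)(C)CC2=O)[C@H](OC(C)=O)[C@@H](OC(C)=O)[C@@H]1OC(C)=O` carries a fully acetylated sugar there; the difference between the two cores is not broken down here. In a functional assay on PBMC cells (Homo sapiens) for inhibition, read by thymidine incorporation, with a stated time of 72 h (on this read-out higher numbers stand for weaker inhibition and lower numbers for stronger inhibition), compound 2 gives 15.8 ug/mL. Compound 1 in this assay gives only a limit, > 50 ug/mL. Compound 3 `CCCCCCCCCCCSC(=S)C1=C(Nc2ccc(Cl)cc2)CC(C)(C)CC1=O` differs from compound 1 by hydrogen in place of chloro on an aromatic carbon. Compound 3 in this assay also gives only a limit, > 50 ug/mL. The step that the two limits leave unreadable from compound 1 to compound 3 therefore cannot be sized, due to the limit of > 50 ug/mL in this assay, at which 2 of the 3 values shown sit.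

Compound 4 `CC(=O)OC[C@H]1O[C@@H](SC(=S)C2=C(Nc3ccc(Cl)cc3)CC(C)(C)CC2=O)[C@H](OC(C)=O)[C@@H](OC(C)=O)[C@@H]1OC(C)=O` is the still unmeasured partner of compound 2 and differs from it by hydrogen in place of chloro on an aromatic carbon. This is the same change as that from compound 1 to compound 3, made on the other core; the two descriptions of the place agree word for word. The step from compound 1 to compound 3 is unreadable, so the data give no measured size for this change. The expectation therefore rests on compound 2 alone. The step of a 1.6-fold higher number from compound 2 to compound 4 (0.20 log units; within the scatter) is estimated to stay small. For compound 4 the expected value in this assay is 25 ug/mL, with a plausible range from 10 ug/mL to 60 ug/mL.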

Compound 4, half-maximal inhibitory concentration: 9.9 ug/mL
Beside the measured number, compound 4's estimate is 2.5-fold (0.40 log units) above it; measured number below the stated range.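

In this assay, the change on the core carrying the fully acetylated sugar gives a 1.6-fold lower number from compound 2 to compound 4 (0.20 log units; within the scatter), so on this core, going from the 2,4-dichlorophenyl group to the 4-chlorophenyl group makes no difference beyond the usual scatter of the measurement. On the core carrying the undecyl chain, the same change from compound 1 to compound 3 cannot be read, and the series therefore offers no second measured size to set beside the first, due to the limit that both of these compounds share: the limit of > 50 ug/mL in this assay, at which 2 of the 4 values shown sit. The result thus describes the change on one core only; it does not show that the change carries from one core to the other, and a single pair within the scatter gives no direction for the effect of removing the chloro.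

The compounds shown leave open whether another group in the place of that chloro, such as a methoxy group or a nitrile, would shift the value on either core. They also leave open how the value would respond on the sulfur to the same sugar with free hydroxyl groups instead of its acetyl groups, or to a shorter chain ending in a carboxylic acid.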